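Extending the amide chain of a farnesylated cysteine diazomethylketone

This account rests on a few compounds, and the source may have more. Where it says the series, first, only, none or still open, it means among the compounds named here.

Compound 2 `CC(C)=CCC/C(C)=C/CC/C(C)=C/CSC[C@H](NC(=O)OC(C)(C)C)C(=O)C=[N+]=[N-]` carries a tert-butoxycarbonyl group on its amide nitrogen. In a functional assay on NALM-6 cells (Homo sapiens) (a lower number here means a stronger inhibitor, a higher number a weaker inhibitor), compound 2 gives 49800 nM, the highest of the three numbers measured, with compound 1 nearest and compound 3 furthest. Compound 1 `CC(=O)N[C@@H](CSC/C=C(\C)CC/C=C(\C)CCC=C(C)C)C(=O)C=[N+]=[N-]`, which bears an acetyl group instead, gives 30300 nM in this assay. The step of a 1.6-fold higher number from compound 1 to compound 2 (0.22 log units; within the scatter) shows that swapping acetyl for tert-butoxycarbonyl does not shift the result beyond the scatter. Within the data shown here, compound 3 `CC(C)=CCC/C(C)=C/CC/C(C)=C/CSC[C@H](NC(=O)OC(C)(C)C)C(=O)CCl` keeps the tert-butoxycarbonyl group but swaps the diazomethyl ketone for a chloromethyl ketone, giving 10700 nM in this assay; the step of a 4.7-fold lower number from compound 2 to compound 3 (0.67 log units; beyond the scatter) is the only change that moves the number clearly.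

Compound 4 `CC(C)=CCC/C(C)=C/CC/C(C)=C/CSC[C@H](NC(=O)CNC(=O)OC(C)(C)C)C(=O)C=[N+]=[N-]` is the next variation: ((tert-butoxycarbonyl)amino)methyl in place of tert-butoxy on a carbonyl carbon. This is a change on the amide side, the same side where the step from compound 1 to compound 2 was tested, and that step stayed within the scatter. Among the measured compounds shown here, no measured step touches a change of this exact kind, so the expectation rests only on the amide side appearing tolerant. Compound 4 is therefore expected to give about 35000 nM in this assay, most likely between 12000 nM and 100000 nM. The expected step of a 1.4-fold lower number from compound 2 to compound 4 (0.15 log units; within the scatter) is small, with little confidence in direction.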

Compound 4, half-maximal inhibitory concentration: 51300 nM
The estimate for compound 4 lay 1.5-fold (0.17 log units) below the measured number, and the stated range covers the measured number.
By their numbers in this assay, from the lowest: compound 3; then compounds 1, 2 and 4 (each within the scatter of the next).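

In this assay, putting ((tert-butoxycarbonyl)amino)methyl, with 1 hydrogen-bond donor, in place of tert-butoxy, with no donor, on a carbonyl carbon gives a 1.0-fold higher number from compound 2 to compound 4 (0.01 log units; within the scatter). Read against the acetyl group, the same compound shows a 1.7-fold higher number from compound 1 to compound 4 (0.23 log units; within the scatter), a step that puts (tert-butoxycarbonyl)amino in place of hydrogen on a saturated chain carbon bound to a carbonyl carbon. The earlier compounds shown here showed only that acetyl and tert-butoxycarbonyl could be exchanged within the scatter, whereas these steps show the same for a clearly bigger group that also adds a hydrogen-bond donor, so all three diazomethyl ketones, compound 1, compound 2 and compound 4, stay within the scatter of one another.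

Nothing measured here explains why this side of the molecule changes the number so little. Still open, going by these compounds, is whether an amine or a carboxylic acid in place of ((tert-butoxycarbonyl)amino)methyl would move the number, and whether the chloromethyl ketone would keep its lower number when paired with that longer group.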